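Swapping the Ring Amine at the Aromatic Carbon

A few compounds are considered here, and "the series" means these few. Any claim that something is new, unique, unknown or untested is made for them only; others in the source may bear on it.

Compound 1 `CCN(CC)c1ccc2cc(NC(=O)CCc3ccc(C(F)(F)F)cc3)ccc2n1`: in a functional assay on HEK293 cells for activation of melanin-concentrating hormone receptor 1 (Rattus norvegicus), read by inositol phosphate accumulation (a higher number here means that more compound is needed for the effect, a lower number that less compound is needed), compound 1 gives 830 nM.
Compound 2 `CNC(=O)NC1CCN(c2ccc3cc(NC(=O)CCc4ccc(C(F)(F)F)cc4)ccc3n2)C1`: compound 2 gives 30 nM.
Compound 3 `O=C(CCc1ccc(C(F)(F)F)cc1)Nc1ccc2nc(N3CC4CCC3CC4)ccc2c1`: compound 3 gives 190 nM.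

Compound 3 holds the second highest of the three numbers. Its nearest neighbour is compound 1, the gap being a 4.4-fold lower number from compound 1 to compound 3 (0.64 log units; beyond the scatter); its furthest is compound 2, the gap being a 6.3-fold higher number from compound 2 to compound 3 (0.80 log units; beyond the scatter).

Compound 4 `O=C(CCc1ccc(C(F)(F)F)cc1)Nc1ccc2nc(N3CC4CC3CO4)ccc2c1` differs from compound 3 in one place: a group of 7 heavy atoms (5 carbon, 1 nitrogen, 1 oxygen; 2 five-membered non-aromatic rings with 1 hetero atom each) in place of a group of 8 heavy atoms (7 carbon, 1 nitrogen; 2 six-membered non-aromatic rings with 1 hetero atom each), on an aromatic carbon. The entering group, as counted, carries an oxygen as well as a nitrogen.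

All three measured steps act at this same aromatic carbon and so bear on the change. a 28-fold lower number from compound 1 to compound 2 (1.44 log units; beyond the scatter) was large; a 4.4-fold lower number from compound 1 to compound 3 (0.64 log units; beyond the scatter) and a 6.3-fold higher number from compound 2 to compound 3 (0.80 log units; beyond the scatter) were modest. Replacements at this carbon have therefore moved the number over a wide span, and the group carrying both oxygen and nitrogen, in compound 2, gave the lowest number of the three. For compound 4 a modest lowering, or no change beyond the scatter, is expected, estimated as a 1.3-fold lower number from compound 3 to compound 4 (0.10 log units; within the scatter). The estimated value for compound 4 in this assay is 150 nM, with a range from 40 nM to 500 nM.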

Compound 4, half-maximal effective concentration: 70 nM
The estimate for compound 4 lay 2.1-fold (0.33 log units) above the measured number; the measured number falls inside the stated range.
By their numbers in this assay, from the lowest: compound 2; then compound 4; then compound 3; then compound 1.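

Within this assay, the step from the group of 8 heavy atoms to the group of 7 heavy atoms gives a 2.7-fold lower number from compound 3 to compound 4 (0.43 log units; beyond the scatter), so replacing one two-ring amine with another that has 2 hydrogen-bond acceptors in place of 1 hydrogen-bond acceptor still shifts the number beyond the scatter. The new group does not fully match the group of 10 heavy atoms, with a 2.3-fold higher number from compound 2 to compound 4 (0.37 log units; beyond the scatter), but it brings the number much closer to that of compound 2 than the earlier two-ring group did. Against the diethylamino group, it gives a 12-fold lower number from compound 1 to compound 4 (1.07 log units; beyond the scatter), and among these four compounds the two groups containing oxygen hold the two lowest numbers, with no compound going against that order.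

The step to compound 4 changes the ring sizes and adds the oxygen together, and a simple morpholine or pyrrolidine at the same carbon would be needed to begin separating those two changes. No evidence is available to explain why the number moved at this position.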